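The compounds below may be only part of what the source reports. "The series", "measured", "known", "first", "only" and "open" are said of these compounds alone.

Working notes on a small set of compounds sharing one core, all read in an assay on isolated protein (Cavia porcellus) with Sigma non-opioid intracellular receptor 1 (Homo sapiens) as the target, read by radioligand binding; a higher number here means a weaker inhibitor, a lower number a stronger inhibitor.

Three have been measured. Compound 1 `O=c1cc(-c2cccnc2)oc2ccc(OCCCCCCN3CCC(O)CC3)cc12` gives 194 nM in this assay. Compound 2 `O=c1cc(C2CCCCC2)oc2ccc(OCCCCCCN3CCC(O)CC3)cc12` gives 88 nM in this assay. Compound 3 `O=c1cc(C2CCCCC2)oc2ccc(OCCCCCCN3CCCCC3)cc12` gives 55 nM in this assay, the lowest of the three numbers, though its gap to compound 2 lies within the scatter and only its gap to compound 1 lies beyond it.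

Two single-point changes connect these. The first, (pyridin-3-yl in place of cyclohexyl on an aromatic carbon), made the step of a 2.2-fold higher number from compound 2 to compound 1 (0.34 log units; beyond the scatter). The second, (hydrogen in place of hydroxy on a saturated ring carbon), made the step of a 1.6-fold lower number from compound 2 to compound 3 (0.20 log units; within the scatter); this is also how the cores of compound 2 and compound 3 differ, and thus how the core of compound 4 differs from that of compound 1.

Compound 4 `O=c1cc(-c2cccnc2)oc2ccc(OCCCCCCN3CCCCC3)cc12` has not yet been measured. It differs from compound 3 by pyridin-3-yl in place of cyclohexyl on an aromatic carbon, the same change as from compound 2 to compound 1, made twice in all among these compounds, at the same place on the core in both cases. A step of similar size, a 2.2-fold higher number from compound 3 to compound 4 (0.34 log units; beyond the scatter), is expected, because the earlier instance gave a 2.2-fold higher number from compound 2 to compound 1 (0.34 log units; beyond the scatter) and nothing here shows the change reading differently on the core of compound 3. On that basis compound 4 is estimated at 120 nM in this assay. The expected range for compound 4 runs from 60 nM to 250 nM.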

Compound 4, half-maximal inhibitory concentration: 119 nM
For compound 4 the middle estimate is 1.0-fold (0.00 log units) above the measured one; the range from low to high includes it.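

In this assay, the new step of a 2.2-fold higher number from compound 3 to compound 4 (0.34 log units; beyond the scatter) repeats the replacement of cyclohexyl by pyridin-3-yl on a second core, and it agrees with the earlier instance: the same change on two cores in this assay, a 2.2-fold higher number (0.34 log units; beyond the scatter) from compound 2 to compound 1 and a 2.2-fold higher number (0.34 log units; beyond the scatter) from compound 3 to compound 4, 1.0-fold (0.01 log units) apart, within the scatter of two such steps. The removal of the hydroxy group also reads alike on both cores, with the new step of a 1.6-fold lower number from compound 1 to compound 4 (0.21 log units; within the scatter) matching the earlier one: the same change on two cores in this assay, a 1.6-fold lower number (0.20 log units; within the scatter) from compound 2 to compound 3 and a 1.6-fold lower number (0.21 log units; within the scatter) from compound 1 to compound 4, 1.0-fold (0.01 log units) apart, within the scatter of two such steps. Across these four compounds, each change can therefore be carried from one core to the other with no sign of dependence on the other position, but this rests on a single pair of cores in one assay, the hydroxy step lies within the scatter on both cores, and nothing here shows why either step has its size or whether it would hold on a core that differs in any other way.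

Going by these compounds, what remains open is whether a phenyl group or a pyridin-4-yl group on the same aromatic carbon would give a step like that of pyridin-3-yl. Also open, on these data alone, is whether the two steps would keep their size with a shorter or longer chain, or with a morpholine in place of the saturated nitrogen ring.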